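The source may report more compounds than this note shows. Statements on the series, on what has been measured and on what is new or still open speak of the compounds shown alone.

Measured in a functional assay on PC-12 cells (Rattus norvegicus) for cytotoxicity, read by MTT assay, with stated times of 3 h and 2 h, tested at 1 uM; on this read-out higher numbers stand for a stronger effect at the one concentration tested and lower numbers for a weaker effect:
Compound 1, `Cc1cc(=O)oc2cc(OCCCn3cc(CNC(=O)CCCCC4CCSS4)nn3)ccc12`, gives 54.5%.
Compound 2, `CCOC(=O)c1cc2ccc(OCCCn3cc(CNC(=O)CCCCC4CCSS4)nn3)cc2oc1=O`, gives 28.3%.
Compound 3, `O=C(CCCCC1CCSS1)NCc1cn(CCCOc2ccc3cc(C(=O)O)c(=O)oc3c2)nn1`, gives 52.1%.

Compound 3 stands with compound 1 inside the scatter of this read-out, and beyond the scatter above compound 2. Among the compounds with values here, the one step that reaches compound 3 is a number 23.8 percentage points higher from compound 2 to compound 3 (beyond the scatter), which shows that the group on this aromatic carbon of the shared core moves the number markedly when the ethyl is exchanged for hydrogen.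

Compound 4, `O=C(CCCCC1CCSS1)NCc1cn(CCCOc2ccc3cc(-c4ccc(Cl)cc4)c(=O)oc3c2)nn1`, is not yet measured. It differs from compound 3 by 4-chlorophenyl in place of carboxy on an aromatic carbon.

Within the data shown here, no measured step exchanges the carboxy for an aromatic ring at this position, so the single step from compound 2 to compound 3 is the only guide, and it speaks for the position being sensitive. Compound 1, carrying only a methyl at this position, stands within the scatter of compound 3, which suggests that loss of the carboxy itself need not cost much. A change of a number 6.1 percentage points lower from compound 3 to compound 4 (within the scatter) in this assay is therefore expected, that is a shift not clearly beyond the scatter, with wide uncertainty. Compound 4 is estimated at 46%, in the range 26% to 66%.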

Compound 4, a percentage reported as activity, at one concentration (the size of the read-out at that concentration, not a potency): 49.3%
Beside the measured number, compound 4's estimate is 3.3 percentage points below it; measured number inside the range.
By their numbers in this assay, from the lowest: compound 2; then compounds 4, 3 and 1 (each within the scatter of the next).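

In this assay, exchanging carboxy for 4-chlorophenyl on this aromatic carbon gives a number 2.8 percentage points lower from compound 3 to compound 4 (within the scatter), so this read-out does not separate two groups that differ in size and in their hydrogen-bond donor, and a six-membered aromatic ring of carbon only is accepted here without a change beyond the scatter. The same 4-chlorophenyl set against ethoxycarbonyl gives a number 21 percentage points higher from compound 2 to compound 4 (beyond the scatter), which means that among the three groups compared at this carbon, ethoxycarbonyl alone stands apart, with compound 2 lower than both compound 3 and compound 4, and the sensitivity of the position now rests on that one group. Nothing available bears on the reason for this separation.

Still open, from the compounds shown here alone, is whether a primary amide or an aminomethyl group on this carbon would stand with compound 3 and compound 4 or with compound 2, and whether a phenyl without the chlorine would stay with compound 4. Going by these compounds, all of these numbers come from a single concentration, so whether compound 3 and compound 4 also stay together at other concentrations remains unknown.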